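Swapping an Aminophenyl for a Dichlorophenyl on the Carbonyl

The compounds below may be only part of what the source reports. "The series", "measured", "known", "first", "only" and "open" are said of these compounds alone.

Compound 1 `COc1cc(-c2cc(/C=C/C(=O)c3ccc(N)cc3)[nH]n2)cc(OC)c1OC` stands at the lower of the two numbers recorded so far in a functional assay on M14 cells (Homo sapiens) for inhibition, read by sulforhodamine B assay, with a stated time of 48 h (a higher number here means a weaker inhibitor of growth, a lower number a stronger inhibitor of growth), where compound 1 gives 1830 nM. Compound 2 `COc1ccc(-c2cc(/C=C/C(=O)c3ccc(OC)c(OC)c3)[nH]n2)cc1` lies close by: in this assay compound 2 gives 2170 nM, and the gap to compound 1 falls within the ordinary scatter, so the two cannot be ranked against each other. Compound 3 `COc1cc(-c2cc(/C=C/C(=O)c3ccc(Cl)c(Cl)c3)[nH]n2)cc(OC)c1OC` has not yet been measured. It differs from compound 1 in a single place: 3,4-dichlorophenyl in place of 4-aminophenyl on a carbonyl carbon. Among the compounds with values here, no measured pair shows what this exchange does on the shared core, so the expectation rests on the two recorded numbers and the change itself. The account expects a modest step, leaning toward weaker growth inhibition, of about a 1.4-fold higher number from compound 1 to compound 3 (0.15 log units; within the scatter), which would sit close to the scatter. For compound 3 the estimate in this assay is 2600 nM, with a range from 800 nM to 8000 nM.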

Compound 3, concentration for 50% growth inhibition: 18200 nM
Compound 3: the middle estimate sits 7.0-fold (0.85 log units) below what was measured; the whole stated range lies below it.
By their numbers in this assay, from the lowest: compounds 1 and 2 (each within the scatter of the next); then compound 3.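

On the shared core, 3,4-dichlorophenyl in place of 4-aminophenyl on a carbonyl carbon gives a 9.9-fold higher number from compound 1 to compound 3 (1.00 log units; beyond the scatter) in this assay and so weaker growth inhibition. This place is therefore not indifferent to the group it carries, something compounds 1 and 2 could not show, since they differ in more than one place and cannot be ranked. The exchange removes the hydrogen-bond donor and acceptor counted on 4-aminophenyl and brings in two chlorines, but nothing measured here explains the rise in the number.

A single pair leaves open whether the step follows from the departure of the amine or from the arrival of the chlorines. A plain phenyl or a hydroxyphenyl on the same carbonyl carbon would help to separate the two.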